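Shifting a Hydroxyphenyl Group Before the Measurement

The source may hold more compounds than are shown below. What is called first, only, known or untested is meant among the compounds shown, and "the series" means these compounds.

Measured compounds:
compound 1 `COc1ccc([C@@H]2CC(c3cccc(O)c3)=NN2c2ccc(S(N)(=O)=O)cc2)cc1` — 64.7%
compound 2 `NS(=O)(=O)c1ccc(N2N=C(c3cccc(O)c3)C[C@H]2c2ccc(O)cc2)cc1` — 64.7%

In a functional assay on the whole organism (strain Wistar albino) for inhibition, with Rattus norvegicus as the target, read by paw edema, with stated times of 30 min and 3 h, at a dose of 0.05 mmol/kg (on this read-out lower numbers stand for less inhibition and higher numbers for more inhibition at the one dose given (going by the name of the read-out)), compound 1 gives 64.7%. Compound 2 stands level with compound 1 at the digits shown; in this assay compound 2 gives 64.7%. Within the data shown here, the one measured step, no change at the digits printed from compound 1 to compound 2 (within the scatter), is hydrogen in place of methyl on an oxygen on an aromatic ring, and it lies within the scatter.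

Compound 3 `NS(=O)(=O)c1ccc(N2N=C(c3cccc(O)c3)C[C@H]2c2ccccc2O)cc1` has not yet been measured in this assay. It differs from compound 2 by 2-hydroxyphenyl in place of 4-hydroxyphenyl on a saturated ring carbon. Among the measured compounds shown here, no measured step bears on this kind of change: the single step known concerns a different group and a different position, and it was flat. The data therefore give no ground to expect a step beyond the scatter in this assay in either direction, though the lack of any comparable step leaves the range wide. The expected step in this assay is a number 4.7 percentage points lower from compound 2 to compound 3 (within the scatter). Compound 3 is estimated at 60%, within 42% to 75%.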

Compound 3, a percentage reported as inhibition, in the whole organism at one dose (the size of the read-out at that dose, not a potency): 35.4%
Compound 3: middle estimate off by 24.6 percentage points, on the high side; measured number outside the range, below it.
By their numbers in this assay, from the lowest: compound 3; then compounds 1 and 2 (each within the scatter of the next).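

In this assay, the saturated ring carbon proves sensitive to which hydroxyphenyl group it carries: 2-hydroxyphenyl in place of 4-hydroxyphenyl gives a number 29.3 percentage points lower from compound 2 to compound 3 (beyond the scatter), although the two groups have the same atoms and the same counts of hydrogen-bond donors and acceptors. The earlier pair showed only that 4-hydroxyphenyl and 4-methoxyphenyl stand level at this carbon, and 2-hydroxyphenyl in place of 4-methoxyphenyl now gives a number 29.3 percentage points lower from compound 1 to compound 3 (beyond the scatter), so among these three compounds only compound 3 stands apart, with both steps beyond the scatter. No measurement available here accounts for this fall in inhibition of paw edema, and the result records the change without giving its cause.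

On these data alone, it remains open whether the lower number belongs to the 2-hydroxyphenyl group alone or would also come with other groups of the same pattern, such as 2-methoxyphenyl or 2-aminophenyl at the same carbon. Since each number is the size of the effect at a single dose, the compounds also leave open whether the step from 4-hydroxyphenyl to 2-hydroxyphenyl would keep its size at other doses.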